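Methyl on the Ring Carbon: A Step Not Yet Measured

A few compounds are considered here, and "the series" means these few. Any claim that something is new, unique, unknown or untested is made for them only; others in the source may bear on it.

Measured so far in a functional assay on cells (Cancer cell lines, Homo sapiens) for inhibition; on this read-out lower numbers stand for stronger inhibition of growth and higher numbers for weaker inhibition of growth:
compound 1 `Cc1cc(-c2nc3n(c2/C=N/NC(=N)N)CCS3)c(C)s1` gives 34700 nM;
compound 2 `N=C(N)N/N=C/c1c(-c2ccsc2)nc2sccn12` gives 28800 nM;
compound 3 `Cc1cn2c(/C=N/Nc3ccccn3)c(-c3ccc(Cl)c([N+](=O)[O-])c3)nc2s1` gives 19500 nM.

Compound 2 stands at the second highest of the three numbers, and the other two values lie within the usual scatter of it on either side, so the three compounds cannot be separated on this read-out. Compound 4 `Cc1cn2c(/C=N/NC(=N)N)c(-c3ccsc3)nc2s1` differs from compound 2 in one place: methyl in place of hydrogen on an aromatic carbon. Going by the values given here, no pair of measured compounds shows this change, so there is no measured step to lean on. With nothing in the data pointing in either direction, the change is expected to leave the number within the scatter, an expected step of a 1.1-fold lower number from compound 2 to compound 4 (0.04 log units; within the scatter). Compound 4 is therefore estimated at 26000 nM in this assay, with a range from 10000 nM to 65000 nM.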

Compound 4, concentration for total growth inhibition: 19500 nM
Beside the measured number, compound 4's estimate is 1.3-fold (0.12 log units) above it, within the range that was stated.
By their numbers in this assay, from the lowest: compounds 3, 4, 2 and 1 (each within the scatter of the next).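

Going by these compounds alone, on this assay, the step of a 1.5-fold lower number from compound 2 to compound 4 (0.17 log units; within the scatter) gives the first direct reading for methyl in place of hydrogen on this aromatic carbon next to the ring sulfur. It shows that this one added carbon leaves the number within the scatter, so the two compounds cannot be told apart on this read-out. No available evidence accounts for the step.

The compounds shown leave open whether an ethyl, a longer chain or an amine at this position would move the number beyond the scatter. They also leave open whether a halogen such as chlorine would do so.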